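Working notes: the step from compound 2 to compound 3

A few compounds are considered here, and "the series" means these few. Any claim that something is new, unique, unknown or untested is made for them only; others in the source may bear on it.

- Compound 1 `O=C(O)CCCC(=O)OCCOc1no[n+]([O-])c1S(=O)(=O)c1ccccc1` gives 4000 nM
- Compound 2 `O=C(O)CCC(=O)OCCCOc1no[n+]([O-])c1S(=O)(=O)c1ccccc1` gives 6400 nM
- Compound 3 `O=C(O)c1ccccc1C(=O)OCCCOc1no[n+]([O-])c1S(=O)(=O)c1ccccc1` is not yet measured

In a functional assay on HepG2 cells (Homo sapiens) for antiproliferative activity, read by MTT assay, with a stated time of 72 h (on this read-out lower numbers stand for stronger inhibition and higher numbers for weaker inhibition), compound 2, at 6400 nM, lies within the scatter of compound 1, at 4000 nM, so the two cannot be told apart on these numbers.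

The change to compound 3 is 2-carboxyphenyl in place of 2-carboxyethyl on a carbonyl carbon in which 2-carboxyphenyl comes in place of 2-carboxyethyl on a carbonyl carbon.

For the measured compounds named here, only one measured step bears on this, a 1.6-fold higher number from compound 1 to compound 2 (0.20 log units; within the scatter) on the same ester chain, and it gives no sign of a large response to a change there. Going by the values given here, it is a weak guide, however, as no measured compound carries 2-carboxyphenyl, so the expected range stays wide.

The estimated step is a 1.3-fold lower number from compound 2 to compound 3 (0.11 log units; within the scatter) in this assay and this means that no change beyond the scatter is expected.

Compound 3 is expected at 5000 nM with an estimated range of 1800 nM to 14000 nM in this assay for this measurement.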

Compound 3, half-maximal inhibitory concentration: > 10000 nM
Compound 3: only a limit was reported; the forecaster's own chance of this, stated with the estimate: 3%; middle value at least 2.0-fold (0.30 log units) away from the limit.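

In this assay, 2-carboxyphenyl in place of 2-carboxyethyl on this carbonyl carbon gives an at least 1.5-fold higher number from compound 2 to compound 3 (0.19 log units; that floor lies within the scatter), which is a floor and not a measured size. Compound 3 is reported only as a limit, > 10000 nM, so the true size of the step cannot be read and the step cannot be placed beyond the scatter. The earlier pair differed only in its ester chain and could not be told apart, whereas this result adds that a six-membered aromatic ring entering on this carbonyl carbon brings no lower number, a reading that rests on a single limit: the limit of > 10000 nM in this assay, at which 1 of the 3 values shown sits.

Still open, going by these compounds, is how far the value of compound 3 lies past its limit, and whether the ring itself or the placing of the carboxylic acid on it governs the outcome, which a cyclohexane ring carrying the same carboxylic acid would help to separate. Also open, on these data alone, is whether the free carboxylic acid matters at all at this end of the chain, a question that a methyl ester or a primary amide in its place would address.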